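A few compounds are considered here, and "the series" means these few. Any claim that something is new, unique, unknown or untested is made for them only; others in the source may bear on it.

Measured in an assay on HEK293 cells for displacement of a labelled ligand from Melanocortin receptor 4 (Homo sapiens); on this read-out lower numbers stand for stronger inhibition and higher numbers for weaker inhibition:

compound 1, `CC(C)C[C@H](N)c1cc(C(F)(F)F)ccc1N1CCN(C(=O)CCNC2CCCCC2)CC1`: 4800 nM
compound 2, `CC(C)C[C@H](N)c1cc(C(F)(F)F)ccc1N1CCN(C(=O)[C@H](C)Cc2ccc(Cl)cc2)CC1`: 31 nM
compound 3, `Cc1ccc(OCC(=O)N2CCN(c3ccc(C(F)(F)F)cc3[C@@H](N)CC(C)C)CC2)c(C)c1`: 4000 nM

Compound 3 holds the second highest of the three numbers. Its nearest neighbour is compound 1, the step being a 1.2-fold lower number from compound 1 to compound 3 (0.08 log units; within the scatter), and its furthest is compound 2, separated by a 130-fold higher number from compound 2 to compound 3 (2.11 log units; beyond the scatter).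

Compound 4, `CC(C)C[C@H](N)c1cc(C(F)(F)F)ccc1N1CCN(C(=O)COc2cccc(Cl)c2)CC1`, differs from compound 3 in one place: 3-chlorophenyl in place of 2,4-dimethylphenyl on an oxygen on a saturated carbon. Neither measured step bears directly on this change. Within the data shown here, the step from compound 1 to compound 3 and the step from compound 2 to compound 3 each exchange the whole group on the carbonyl carbon, not the aryl on the oxygen alone, and no measured pair varies a 2,4-dimethylphenoxy against a 3-chlorophenoxy. Without a comparable step, compound 4 is expected to stay near compound 3, with a step of a 1.3-fold lower number from compound 3 to compound 4 (0.12 log units; within the scatter) not reaching beyond the usual scatter in this assay. The estimate for compound 4 in this assay is therefore 3000 nM, with a range from 700 nM to 13000 nM.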

Compound 4, inhibition constant: 2600 nM
The estimate for compound 4 lay 1.2-fold (0.06 log units) above the measured number, and the stated range covers the measured number.
By their numbers in this assay, from the lowest: compound 2; then compounds 4, 3 and 1 (each within the scatter of the next).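

In this assay, among these compounds, the exchange of 2,4-dimethylphenyl for 3-chlorophenyl on the oxygen gives a 1.5-fold lower number from compound 3 to compound 4 (0.19 log units; within the scatter), the first reading of an aryl change alone at this position, and it shows no separation between these two aryl groups. A chlorine on the phenoxy aryl does not close the gap to the 1-(4-chlorobenzyl)ethyl compound, with an 84-fold higher number from compound 2 to compound 4 (1.92 log units; beyond the scatter), and the result stays level with the cyclohexylamino compound, with a 1.8-fold lower number from compound 1 to compound 4 (0.27 log units; within the scatter). No supporting evidence bears on why this aryl exchange leaves the number within the scatter.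

The compounds shown leave open whether a 4-chlorophenoxy group would behave like 3-chlorophenoxy. They also leave open whether a plain carbon chain in place of the ether oxygen, or a methyl branch on the carbon bound to the carbonyl, would move the number toward that of compound 2, 31 nM.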